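Extending the hydroxycarbamoyl chain of compound 1

The compounds below may be only part of what the source reports. "The series", "measured", "known", "first", "only" and "open" are said of these compounds alone.

In a functional assay on HCT-116 cells (Homo sapiens) for inhibition, read by MTT assay, with a stated time of 72 h (on this read-out lower numbers stand for stronger inhibition and higher numbers for weaker inhibition), compound 1 (`COc1cc2c(Oc3ccc(NC(=O)c4nn(-c5ccccc5C)cc(C)c4=O)cc3)ccnc2cc1OCCCC(=O)NO`) gives 640 nM. Compound 2 (`COc1cc2c(Oc3ccc(NC(=O)c4nn(-c5ccccc5F)cc(C)c4=O)cc3F)ccnc2cc1OCCCCCC(=O)NO`) gives 590 nM and compound 3 (`COc1cc2c(Oc3ccc(NC(=O)c4nn(-c5ccccc5)ccc4=O)cc3)ccnc2cc1OCCCC(=O)NO`) gives 940 nM, so compound 1 stands within the scatter of both. The change to compound 4 (`COc1cc2c(Oc3ccc(NC(=O)c4nn(-c5ccccc5C)cc(C)c4=O)cc3)ccnc2cc1OCCCCCC(=O)NO`) is 2-(hydroxycarbamoyl)ethyl in place of hydroxycarbamoyl on a saturated chain carbon, three bonds along the chain from an oxygen on an aromatic ring. Read one bond further out, this is 3-(hydroxycarbamoyl)propyl to 5-(hydroxycarbamoyl)pentyl. Among the compounds with values here, no measured pair isolates this change. Within the data shown here, compound 2, the only measured compound carrying 5-(hydroxycarbamoyl)pentyl, gives 590 nM, so in this assay only a small step toward a lower number is expected, probably none beyond the scatter. The expected step is a 1.3-fold lower number from compound 1 to compound 4 (0.12 log units; within the scatter). For compound 4 the estimated value is 480 nM, with an expected range of 220 nM to 1000 nM.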

Compound 4, half-maximal inhibitory concentration: 290 nM
The estimate for compound 4 lay 1.7-fold (0.22 log units) above the measured number, within the range that was stated.
By their numbers in this assay, from the lowest: compound 4; then compounds 2, 1 and 3 (each within the scatter of the next).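

In this assay the change from 3-(hydroxycarbamoyl)propyl to 5-(hydroxycarbamoyl)pentyl gives a 2.2-fold lower number from compound 1 to compound 4 (0.34 log units; beyond the scatter) with the rest of the structure held constant. Chain length at this position therefore affects the read-out, which compound 1, compound 2 and compound 3 could not show, since they differ from one another in more than one place. No measurement here accounts for the step. Within the data shown here, only one pair of chain lengths is compared, so the course through 4-(hydroxycarbamoyl)butyl or on to a longer chain stays open. From the compounds shown here alone, whether a carboxylic acid could replace the terminal hydroxycarbamoyl also stays open.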